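Chloro to methoxy on two indole-type scaffolds compared

The compounds below may be only part of what the source reports. "The series", "measured", "known", "first", "only" and "open" are said of these compounds alone.

Compound 1 `Fc1ccc(-c2[nH]c3cc(Cl)ccc3c2Cn2ccnc2)cc1` was tested in an ADME assay on MCF7 cells (Homo sapiens) for cytotoxicity, read by MTT assay, with a stated time of 48 h (on this read-out higher numbers stand for weaker inhibition and lower numbers for stronger inhibition), and gives 41500 nM. Compound 2 `COc1ccc2c(Cn3ccnc3)c(-c3ccc(F)cc3)[nH]c2c1` differs from compound 1 by methoxy in place of chloro on an aromatic carbon. In this assay compound 2 gives only a limit, > 1000000 nM, and no number. The step from compound 1 to compound 2 is thus an at least 24-fold higher number from compound 1 to compound 2 (1.38 log units; beyond the scatter), a limit rather than a measured value setting its lower bound; this rests on (the limit of > 1000000 nM in this assay, at which 2 of the 3 values shown sit).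

Compound 3 `Fc1ccc2c(Cn3cncn3)c(-c3ccc(Cl)cc3)[nH]c2c1` belongs to a second core. The difference between the two cores is not broken down here. In this assay compound 3 gives only a limit, > 1000000 nM, and no number. Compound 4 `COc1ccc(-c2[nH]c3cc(F)ccc3c2Cn2cncn2)cc1`, not yet measured, differs from compound 3 by methoxy in place of chloro on an aromatic carbon. This is the same kind of change as that from compound 1 to compound 2, but not the same: in compound 2 the methoxy sits on an aromatic carbon of a six-membered aromatic ring of carbon only, part of a fused or bridged system of two rings, meta to a fused ring and para to a fused ring, whereas in compound 4 it sits on a six-membered aromatic ring of carbon only, para to a large group.

Because compound 3 already gives only the limit > 1000000 nM, the step from compound 3 to compound 4 is expected to be a step that the limit leaves unreadable from compound 3 to compound 4, and the result for compound 4 is expected to remain a limit. Compound 4 is therefore estimated at 1500000 nM, between 200000 nM and 10000000 nM.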

Compound 4, half-maximal inhibitory concentration: 325000 nM
The estimate for compound 4 lay 4.6-fold (0.66 log units) above the measured number, within the range that was stated.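

The change of chloro to methoxy gives an at least 3.0-fold lower number from compound 3 to compound 4 (0.48 log units; beyond the scatter) in this assay, and this runs against the earlier step on the other core, so the change does not carry over between these two cores with a fixed size or even a fixed direction: the same change on two cores in this assay, an at least 24-fold higher number (1.38 log units; beyond the scatter) from compound 1 to compound 2 and an at least 3.0-fold lower number (0.48 log units; beyond the scatter) from compound 3 to compound 4, at least 74-fold (1.87 log units) apart, beyond the scatter of two such steps

Each of the two steps has a limit at one end, so both sizes are known only as bounds and not as measured differences: the limit of > 1000000 nM in this assay, at which 2 of the 4 values shown sit.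

What the pair does not show is why the two steps part, since the cores differ and the methoxy also stands at a different place in each pair, in compound 4 on a six-membered aromatic ring of carbon only, para to a large group, and in compound 2 elsewhere in the molecule.

The compounds shown leave open whether the same swap, made at that same place on the core of compound 1, would also lower the number, which would separate the effect of the core from that of the place. They also leave open whether other groups in place of the chloro of compound 3, such as an amine or a carboxylic acid, would lower the number in the same way as methoxy.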